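The compounds below may be only part of what the source reports. "The series", "measured", "known", "first", "only" and "open" are said of these compounds alone.

In a functional assay on HCT-15 cells (Homo sapiens) for antiproliferative activity, read by MTT assay, with a stated time of 72 h (on this read-out higher numbers stand for weaker inhibition and lower numbers for stronger inhibition), compound 1 (`COc1cc(-c2nccn2C(C)C)cc(OC)c1OC`) gives only a limit, > 100000 nM. Compound 3 (`COc1cc(OC)cc(-n2ccnc2-c2cc(OC)c(OC)c(OC)c2)c1`) also gives only a limit, > 100000 nM. Compound 1 therefore stands at the limit of > 100000 nM in this assay, at which 2 of the 3 values shown sit. Compound 2 (`COc1cc(-c2nccn2-c2ccc3cc[nH]c3c2)cc(OC)c1OC`) gives a true number, 4000 nM. Compound 4 (`COc1cc(-c2nccn2-c2ccc(F)cc2)cc(OC)c1OC`) has 4-fluorophenyl in place of isopropyl on an aromatic nitrogen. Compound 2, at 4000 nM, shows that a measurable value is possible among these compounds, so some gain in inhibition is expected, although compound 3 shows that a measurable value is not assured. The expected change, towards stronger inhibition, is an at least 5.0-fold lower number from compound 1 to compound 4 (0.69 log units; beyond the scatter). For compound 4 the estimate is 20000 nM, with an expected range of 3000 nM to 100000 nM.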

Compound 4, half-maximal inhibitory concentration: 68600 nM
For compound 4 the middle estimate is 3.4-fold (0.54 log units) below the measured one; measured number inside the range.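

In this assay, placing 4-fluorophenyl instead of isopropyl on this aromatic nitrogen gives an at least 1.4-fold lower number from compound 1 to compound 4 (0.16 log units; that floor lies within the scatter). This shows that a fluorinated six-membered aromatic ring at this position can bring a measurable value, although the floor of the step does not clear the usual scatter. The true size of the step cannot be read because compound 1 gives only a limit: the limit of > 100000 nM in this assay, at which 2 of the 4 values shown sit.

The compounds shown leave open what plain phenyl, an amine or a carboxylic acid on this nitrogen would give. They also leave open how much of the step belongs to the fluorine rather than to the ring.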